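Working notes: aryl change from compound 2 to compound 3

The source may report more compounds than this note shows. Statements on the series, on what has been measured and on what is new or still open speak of the compounds shown alone.

In a functional assay on HeLa cells (Homo sapiens) for antiproliferative activity, read by MTT assay, with a stated time of 72 h (a higher number here means a weaker inhibitor, a lower number a stronger inhibitor), compound 1 `CCNC(=O)c1cc(Oc2ccc(NC(=O)c3nn(-c4ccccc4OC(F)(F)F)c(=O)cc3C)cc2)ccn1` gives 3990 nM and compound 2 `CCCNC(=O)c1cc(Oc2ccc(NC(=O)c3nn(-c4ccc(C)cc4)c(=O)cc3C)cc2F)ccn1` gives 14200 nM. Compound 2 therefore has the higher of the two numbers, with a gap beyond the scatter. Compound 3 `CCCNC(=O)c1cc(Oc2ccc(NC(=O)c3nn(-c4ccc(Br)cc4F)c(=O)cc3C)cc2F)ccn1` differs from compound 2 as follows: 4-bromo-2-fluorophenyl in place of 4-methylphenyl on an aromatic nitrogen. The 4-bromo-2-fluorophenyl group replaces 4-methylphenyl on an aromatic nitrogen. For the measured compounds named here, no measured step isolates this change, and compounds 1 and 2 differ in more than one place. A small move toward a lower number in this assay is expected, with the estimated step of a 1.9-fold lower number from compound 2 to compound 3 (0.28 log units; within the scatter). For compound 3 the expected value is 7500 nM, with an estimated range of 2500 nM to 20000 nM.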

Compound 3, half-maximal inhibitory concentration: 53500 nM
Beside the measured number, compound 3's estimate is 7.1-fold (0.85 log units) below it, and the stated range ends below it.
By their numbers in this assay, from the lowest: compound 1; then compound 2; then compound 3.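

For the compounds shown here, on the aromatic nitrogen of the shared core, 4-bromo-2-fluorophenyl in place of 4-methylphenyl gives a 3.8-fold higher number from compound 2 to compound 3 (0.58 log units; beyond the scatter) in this assay, the first step that isolates a single place. The readout at this position therefore depends on the aryl group, and this change moves it toward a weaker inhibitor. No evidence on hand accounts for the rise. Bromine and fluorine enter together, so the compounds shown leave open which of the two carries the step. From the compounds shown here alone, how an unsubstituted phenyl or a pyridyl group on the same nitrogen would read in this assay also remains open.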